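Sulfonamide variation on a chromenone enaminone scaffold

The source may hold more compounds than are shown below. What is called first, only, known or untested is meant among the compounds shown, and "the series" means these compounds.

The shared core of compound 1 `CC(=O)NS(=O)(=O)c1ccc(N/C=C\C(=O)c2cc3ccccc3oc2=O)cc1` carries an acetyl group on the sulfonamide nitrogen. In a functional assay on T47D cells (Homo sapiens) for cytotoxicity, read by sulforhodamine B assay, with a stated time of 48 h (on this read-out higher numbers stand for weaker inhibition and lower numbers for stronger inhibition), compound 1 gives no result reported, so it gives no fixed point for the series. Compound 2 `Cc1cc(NS(=O)(=O)c2ccc(N/C=C\C(=O)c3cc4ccccc4oc3=O)cc2)on1` carries a methylisoxazolyl group at the same nitrogen; in this assay compound 2 gives 75600 nM, a weak result. Compound 3 `Cc1nnc(NS(=O)(=O)c2ccc(N/C=C\C(=O)c3cc4ccccc4oc3=O)cc2)s1` is the next variation: 5-methyl-1,3,4-thiadiazol-2-yl in place of acetyl on a sulfonamide nitrogen. The change introduces a heteroaromatic ring of the kind already present in compound 2, and nothing measured separates compound 1 from either. For the measured compounds named here, no step can be computed here; the expectation is that the change from compound 1 to compound 3 moves the half-maximal inhibitory concentration in this assay at most modestly, with no clear direction beyond the scatter. Compound 3 is therefore estimated at 70000 nM in this assay, with a range from 25000 nM to 200000 nM.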

Compound 3, half-maximal inhibitory concentration: 94000 nM
The estimate for compound 3 lay 1.3-fold (0.13 log units) below the measured number, within the range that was stated.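

In this assay, for the compounds shown here, 5-methyl-1,3,4-thiadiazol-2-yl in place of 3-methyl-1,2-oxazol-5-yl on a sulfonamide nitrogen gives a 1.2-fold higher number from compound 2 to compound 3 (0.09 log units; within the scatter), the first step that can be read. At this position, the two ring groups therefore cannot be told apart in this read-out, while any step involving compound 1 and its acetyl group cannot be read, as compound 1 has no number. No measurement shown offers an explanation for this result.

The compounds shown leave open whether any group on this nitrogen can move the number beyond the scatter. A plain phenyl ring, a pyridine ring or a chain ending in a carboxylic acid at the same place would test this, and the bare sulfonamide with hydrogen on that nitrogen remains the missing reference point.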